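This account rests on a few compounds, and the source may have more. Where it says the series, first, only, none or still open, it means among the compounds named here.

Measured compounds in a functional assay on DU-145 cells (Homo sapiens) for inhibition, read by trypan blue exclusion, with a stated time of 96 h; on this read-out higher numbers stand for weaker inhibition of growth and lower numbers for stronger inhibition of growth:
compound 1 `CN(C)c1ccc(/C=C(/SCc2ccc(Cl)cc2)C(=O)c2ccc(Br)cc2)cc1` — 10000 nM
compound 2 `CN(C)c1ccc(/C=C(/SCc2ccc(Cl)cc2)C(=O)c2ccc([N+](=O)[O-])cc2)cc1` — a limit, > 100000 nM
compound 3 `CN(C)c1ccc(/C=C(/SCc2ccc(Cl)cc2)C(=O)c2ccc(Cl)cc2)cc1` — a limit, > 100000 nM

Compound 2 stands only at a limit of this assay, not at a number, and it shares that standing with compound 3, since (the limit of > 100000 nM in this assay, at which 2 of the 3 values shown sit). Compound 1 alone gives a number, and the steps of an at least 10-fold higher number from compound 1 to compound 2 (1.00 log units; beyond the scatter) and an at least 10-fold higher number from compound 1 to compound 3 (1.00 log units; beyond the scatter) both concern a group on the benzoyl ring. Compound 4 `COc1ccccc1/C=C(/SCc1ccc(Cl)cc1)C(=O)c1ccc([N+](=O)[O-])cc1` differs from compound 2 at another place: 2-methoxyphenyl in place of 4-(dimethylamino)phenyl on a double-bonded chain carbon bound to a double-bonded chain carbon. No measured step touches that position, so the direction and size of the change cannot be read from the steps shown; compound 2 itself offers only a limit as a starting point. Compound 4 is therefore expected to remain near that limit, with the step of a number no higher from compound 2 to compound 4 (the limit leaves the size open) estimated at about none beyond the scatter. The estimate for compound 4 in this assay is 100000 nM, in the range 20000 nM to 300000 nM.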

Compound 4, concentration for 50% growth inhibition: 10000 nM
Estimate against measurement, compound 4: 10-fold (1.00 log units) above; the whole stated range lies above it.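

In this assay, within the data shown here, the change on the double-bonded chain carbon gives an at least 10-fold lower number from compound 2 to compound 4 (1.00 log units; beyond the scatter), so this position, which no earlier step touched, clearly bears on growth inhibition. It also shows that a compound with the nitro-substituted benzoyl ring need not sit at the limit. The full size of the step stays unknown because compound 2 has only a limit as its value: the limit of > 100000 nM in this assay, at which 2 of the 4 values shown sit.

The compounds shown leave open whether the step comes from gaining the methoxy group or from losing the dimethylamino group, and whether it would hold with bromo on the benzoyl ring. Going by these compounds, how a hydroxy group or an amine such as morpholine would read at this position also remains open.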